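A few compounds are considered here, and "the series" means these few. Any claim that something is new, unique, unknown or untested is made for them only; others in the source may bear on it.

Compound 1 `Nc1cc(N)c2nc(-c3ccccc3)c(Oc3ccc(Cl)c(Cl)c3)nc2c1`: < 100000 nM
Compound 2 `CCOC(=O)[C@H](CCC(=O)O)NC(=O)c1ccc(Oc2nc3cc(N)cc(N)c3nc2-c2ccccc2)cc1`: < 100000 nM

In a functional assay on NCI-H460 cells (Homo sapiens) for inhibition, read by sulforhodamine B assay, with a stated time of 48 h (a lower number here means that less compound is tolerated, a higher number that more compound is tolerated), compound 1 gives < 100000 nM, which is a limit of the assay rather than a measured number. Compound 2 gives < 100000 nM in this assay, again a limit. Among the measured compounds shown here, compound 1 therefore stands exactly where the only other measured compound stands: both sit at the limit of < 100000 nM in this assay, at which 2 of the 2 values shown sit, and how far below that limit either of them actually lies is not known.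

Compound 3 `Nc1cc(N)c2nc(-c3ccccc3)c(NCc3ccc(F)cc3)nc2c1` differs from compound 1 by (4-fluorobenzyl)amino in place of 3,4-dichlorophenoxy on an aromatic carbon. For the measured compounds named here, no step between two measured compounds is available here, so there is nothing that shows how an exchange of this kind shifts the lethal concentration read out in this assay, and two limits alone give no direction. The step from compound 1 to compound 3 is therefore expected to be a step that the limit leaves unreadable from compound 1 to compound 3, with no direction that can be argued from the data. For compound 3 the expected value in this assay is 10000 nM, within a range from 1000 nM to 80000 nM, and a limit instead of a number remains a real possibility.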

Compound 3, concentration lethal to 50% of the cells: < 100000 nM
Compound 3 was reported as a limit; the forecaster's own chance of this, stated with the estimate: 50%; the middle value is on the limit's open side.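

No step can be read from compound 1 to compound 3 in this assay, because both are reported only as limits, not numbers: the limit of < 100000 nM in this assay, at which 3 of the 3 values shown sit. The compounds shown leave open how far under that limit each really lies, and so whether (4-fluorobenzyl)amino or 3,4-dichlorophenoxy gives the lower lethal concentration.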